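Acetoxymethyl replacing bromo on the imidazole carbon

The source may report more compounds than this note shows. Statements on the series, on what has been measured and on what is new or still open speak of the compounds shown alone.

Measured compounds, with the inhibition they give in a functional assay on the whole organism with Rattus norvegicus as the target, with a stated time of 4 h, at a dose of 40 mg/kg by the intraperitoneal route; on this read-out higher numbers stand for more inhibition at the one dose given (going by the name of the read-out) and lower numbers for less inhibition:
compound 1 `COCc1c(C)nc2c(OCc3ccccc3)cccn12`: 99%
compound 2 `Cc1nc2c(OCc3ccccc3)cccn2c1CS(C)(=O)=O`: 61%
compound 3 `Cc1nc2c(OCc3ccccc3)cccn2c1Br`: 26%

Compound 3 stands lowest of the three in this assay; its nearest neighbour is compound 2, its furthest compound 1, and both lie beyond the scatter above it.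

Compound 4 `CC(=O)OCc1c(C)nc2c(OCc3ccccc3)cccn12` is not yet measured. It differs from compound 3 in one place: acetoxymethyl in place of bromo on an aromatic carbon. The change sits on an aromatic carbon of the five-membered ring, next to the ring nitrogen and next to the ring atom that bears the methyl group.

Within the data shown here, two measured steps bear on this change. The step of a number 73 percentage points lower from compound 1 to compound 3 (beyond the scatter) shows that bromo in place of methoxymethyl at this carbon costs a large part of the inhibition, and the step of a number 35 percentage points lower from compound 2 to compound 3 (beyond the scatter) shows the same direction when bromo replaces (methylsulfonyl)methyl. Acetoxymethyl, like methoxymethyl, is a one-carbon chain bearing oxygen on that aromatic carbon, so the return from bromo to such a chain is expected to recover most of what the step from compound 1 to compound 3 lost. The expected step is therefore large and upward, a number 59 percentage points higher from compound 3 to compound 4 (beyond the scatter).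

Compound 4 is estimated at 85% in this assay, within a range of 55% to 100%.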

Compound 4, a percentage reported as inhibition, in the whole organism at one dose (the size of the read-out at that dose, not a potency): 88%
The estimate for compound 4 lay 3 percentage points below the measured number; low and high end bracket the measured number.
By their numbers in this assay, from the lowest: compound 3; then compound 2; then compound 4; then compound 1.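

At this aromatic carbon, a number 62 percentage points higher from compound 3 to compound 4 (beyond the scatter) in this assay is the step for acetoxymethyl in place of bromo, so the recovery over bromo is not confined to methoxymethyl and now holds for a second one-carbon chain bearing oxygen. The end of the chain also counts: a number 11 percentage points lower from compound 1 to compound 4 (beyond the scatter) is a modest step for acetyl in place of methyl on the oxygen, and a number 27 percentage points higher from compound 2 to compound 4 (beyond the scatter) is a modest step for acetoxy in place of methylsulfonyl. Among the three chains on this carbon, in this assay, acetoxymethyl therefore stands between (methylsulfonyl)methyl and methoxymethyl, with both gaps beyond the scatter, and all three stand above bromo.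

The compounds shown leave open whether hydroxymethyl, an aminomethyl group or a longer chain such as ethoxymethyl on this carbon would stand with the two chains bearing oxygen or nearer to bromo, and whether this order would hold at other doses or times. Nothing at hand accounts for the order of these chains or for the gap to bromo.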